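This account rests on a few compounds, and the source may have more. Where it says the series, first, only, none or still open, it means among the compounds named here.

Measured compounds in a functional assay on EMT6 cells (Mus musculus) for cytotoxicity, with a stated time of 4 h; on this read-out higher numbers stand for weaker inhibition and lower numbers for stronger inhibition:
- compound 1, `CS(=O)(=O)N1CC(CCl)c2ccc(O)cc21`, gives 7700 nM
- compound 2, `CS(=O)(=O)N1CC(CCl)c2ccc(N)cc21`, gives 33000 nM
- compound 3, `CN(C)c1ccc2c(c1)N(S(C)(=O)=O)CC2CCl`, gives 20000 nM

Compound 3 stands second highest of the three numbers in this assay: its nearest neighbour is compound 2, the furthest is compound 1, and the step of a 1.7-fold lower number from compound 2 to compound 3 (0.22 log units; within the scatter) lies within the scatter, while a 2.6-fold higher number from compound 1 to compound 3 (0.41 log units; beyond the scatter) lies beyond it.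

Compound 4, `CS(=O)(=O)N1CC(CCl)c2ccc(S)cc21`, is not yet measured. It differs from compound 3 by sulfanyl in place of dimethylamino on an aromatic carbon.

Going by the values given here, no measured step involves a sulfanyl group. Among the compounds with values here, the steps that bear on this position are a 4.3-fold higher number from compound 1 to compound 2 (0.63 log units; beyond the scatter) and a 2.6-fold higher number from compound 1 to compound 3 (0.41 log units; beyond the scatter), both modest rises in number when hydroxy gives way to a nitrogen-bearing group, and a 1.7-fold lower number from compound 2 to compound 3 (0.22 log units; within the scatter), which lies within the scatter. The entering sulfanyl group, like hydroxy in compound 1, carries one hydrogen-bond donor, so a number between that of compound 1 and compound 3 seems plausible, but the data give no direct anchor.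

Compound 4 is therefore expected to give about 11000 nM in this assay, within 4000 nM to 30000 nM, an estimated step of a 1.8-fold lower number from compound 3 to compound 4 (0.26 log units; within the scatter).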

Compound 4, half-maximal inhibitory concentration: > 200000 nM
Compound 4: only a limit was reported; the forecaster's own chance of this, stated with the estimate: 5%; at least 18-fold (1.25 log units) between middle value and limit.
By their numbers in this assay, from the lowest: compound 1; then compounds 3 and 2 (each within the scatter of the next). At a limit, above all of these: compound 4.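

In this assay, compound 4 is reported only as a limit: the limit of > 200000 nM in this assay, at which 1 of the 4 values shown sits.

Hydroxy, amino and dimethylamino gave only modest steps at this position, whereas sulfanyl gives an at least 10-fold higher number from compound 3 to compound 4 (1.00 log units; beyond the scatter), an at least 6.0-fold higher number from compound 2 to compound 4 (0.78 log units; beyond the scatter) and an at least 25-fold higher number from compound 1 to compound 4 (1.41 log units; beyond the scatter). All three are minimum sizes, and the last, the only one rated large, comes from exchanging oxygen for sulfur. Going by these compounds alone, this position is therefore far more sensitive to the group on the aromatic carbon than the earlier compounds showed.

On these data alone, the real value of compound 4 remains unknown, so the full size of these steps stays open. Also open, as far as these compounds go, is whether the loss follows sulfur itself or the free sulfanyl hydrogen, a question that a methylsulfanyl group set against a methoxy group on the same core could address.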